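Bromo to Methyl: Predicting Compound 4

The source may hold more compounds than are shown below. What is called first, only, known or untested is meant among the compounds shown, and "the series" means these compounds.

Compound 1 `S=C(N/N=C/c1ccc2ccccc2n1)Nc1ccc(Br)cc1` — in a functional assay on HL-60 cells (Homo sapiens) for antiproliferative activity, read by sulforhodamine B assay, with a stated time of 72 h (on this read-out higher numbers stand for weaker inhibition and lower numbers for stronger inhibition), compound 1 gives 27500 nM.
Compound 2 `CN(C)C(=S)N/N=C/c1ccc2ccccc2n1` — compound 2 gives 50 nM.
Compound 3 `CN(C)C(=S)N/N=C/c1cc2cccnc2s1` — compound 3 gives > 100000 nM, which is a limit of the assay rather than a number.

Of the two compounds with a true number, compound 1 stands highest: compound 2 sits far lower, a gap well beyond the usual scatter. Compound 3 is recorded only at the limit of > 100000 nM in this assay, at which 1 of the 3 values shown sits, so it cannot be ranked against the others with a number.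

Compound 4 `Cc1ccc(NC(=S)N/N=C/c2ccc3ccccc3n2)cc1` has not been measured. It differs from compound 1 in one place: methyl in place of bromo on an aromatic carbon. Going by the values given here, no measured pair here shows the effect of this particular swap, and compound 2 differs from compound 1 elsewhere, so the three measured values offer no direct guide to its size. Both compound 1 and compound 4 keep the same shared core and the same attachment pattern, and the change is small in what it adds and removes. The expectation is therefore a step from compound 1 to compound 4 of about a 1.1-fold higher number from compound 1 to compound 4 (0.04 log units; within the scatter), that is, none beyond the scatter.

Compound 4 is expected to give about 30000 nM in this assay, with a likely range from 8000 nM to 100000 nM.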

Compound 4, half-maximal inhibitory concentration: 78300 nM
Beside the measured number, compound 4's estimate is 2.6-fold (0.42 log units) below it, and the stated range covers the measured number.
By their numbers in this assay, from the lowest: compound 2; then compound 1; then compound 4. At a limit, above all of these: compound 3.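

Going by these compounds alone, exchanging one heavy atom for another at this place on the ring gives a 2.8-fold higher number from compound 1 to compound 4 (0.45 log units; beyond the scatter) in this assay and so provides the first measured reading of a change at this position. The counts of heavy atoms, rings, hydrogen-bond donors and hydrogen-bond acceptors are the same on both sides of the swap, yet the step is modest rather than absent, so this position responds to the identity of its group even when those counts stay level. None of the information available on these compounds bears on why the number moves in this direction.

With only bromo and methyl shown at this position, the two give a single step, which cannot reveal a trend, and it remains open whether a chlorine, a methoxy group or an amine there would give a number closer to that of compound 1, closer to that of compound 4 or outside both. On these data alone, it is also open whether the same swap would give a step of similar size on the ring of a compound with a different core.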